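Carbamate chain substitution on the shared aziridinyl core

This account rests on a few compounds, and the source may have more. Where it says the series, first, only, none or still open, it means among the compounds named here.

Compound 2 `CCC1=C(N2CC2)C(=O)C(CCOC(N)=O)=C(N2CC2)C1=O` gives 4.88 in a functional assay on L1210 cells (Mus musculus), with a stated time of 1 days (on this read-out higher numbers stand for higher potency (the scale is a negative logarithm) and lower numbers for lower potency), the second highest of the three numbers in hand. Compound 1 `CC1=C(N2CC2)C(=O)C(N2CC2)=C(N2CC2)C1=O` gives 5.69, and compound 3 `CCCC1=C(N2CC2)C(=O)C(CCOC(N)=O)=C(N2CC2)C1=O` gives 4.42. Among the compounds with values here, the one single-point step available, methyl in place of hydrogen on a saturated chain carbon two bonds along the chain from a double-bonded ring carbon, ran a number 0.46 log units lower from compound 2 to compound 3 (beyond the scatter).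

Compound 4 `CCC1=C(N2CC2)C(=O)C(C(COC(N)=O)OC)=C(N2CC2)C1=O` is not yet measured. It differs from compound 2 by methoxy in place of hydrogen on a saturated chain carbon bound to a double-bonded ring carbon and a saturated chain carbon. Within the data shown here, no measured step places a methoxy on this chain; the step from compound 2 to compound 3 is the only one that adds a group to the carbamate-bearing chain, and it lowered the read-out modestly. Among the measured compounds shown here, on that basis a modest fall is expected for compound 4, estimated as a number 0.33 log units lower from compound 2 to compound 4 (beyond the scatter), with a wide range since the entering group is unlike the one in the measured step. Compound 4 is therefore expected to give about 4.55, estimated between 4 and 5.1.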

Compound 4, logarithm of the reciprocal of the active concentration, log(1/C): 4.92
Compound 4: middle estimate off by 0.37 log units, on the low side, and the stated range covers the measured number.
By their numbers in this assay, from the lowest: compound 3; then compounds 2 and 4 (each within the scatter of the next); then compound 1.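

In this assay, the carbamate-bearing chain accepts methoxy in place of hydrogen on a saturated chain carbon bound to a double-bonded ring carbon and a saturated chain carbon, with the read-out staying within the scatter (a number 0.04 log units higher from compound 2 to compound 4 (within the scatter)). The earlier single-point step was a methyl in place of hydrogen on a saturated chain carbon two bonds along the chain from a double-bonded ring carbon, and it showed a drop beyond the scatter (a number 0.46 log units lower from compound 2 to compound 3 (beyond the scatter)); the new step shows that an added group does not lower the read-out at every chain carbon. Nothing on hand gives a reason for this flat result.

From the compounds shown here alone, whether the same carbon also accepts a hydroxyl, an amine or a longer alkoxy chain remains open. Also open, going by these compounds, is whether methoxy at this carbon stays as flat when the chain on the other side of the core is the longer one of compound 3.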